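This account rests on a few compounds, and the source may have more. Where it says the series, first, only, none or still open, it means among the compounds named here.

Compound 1, `Cc1ccc(CC(C)CNC(=O)/N=C(\N)NCCCc2sc(N)nc2C)cc1`: 132 nM
Compound 2, `Cc1nc(N)sc1CCCN/C(N)=N/C(=O)NC1CCCCC1`: 389 nM
Compound 3, `Cc1nc(N)sc1CCCN/C(N)=N/C(=O)NC(C)c1cccc(F)c1`: 64.6 nM

In a functional assay on HEK293T cells for agonist activity at histamine H2 receptor (Homo sapiens), read by beta-arrestin recruitment (on this read-out higher numbers stand for an effect only at larger amounts of compound and lower numbers for an effect already at smaller amounts), compound 2 gives 389 nM, the highest of the three numbers. Its nearest neighbour is compound 1, which gives 132 nM, a gap beyond the scatter. Compound 3 lies furthest away with 64.6 nM, also beyond the scatter. Compound 4, `CCCCCNC(=O)/N=C(\N)NCCCc1sc(N)nc1C`, has not yet been measured. It differs from compound 2 in a single place: pentyl in place of cyclohexyl on an amide-type nitrogen. Cut one bond further out, the same change reads cyclohexylamino to pentylamino. Going by the values given here, no measured pair shows this change on its own, and the three measured compounds each carry a different group on the amide-type nitrogen, so no direct precedent for a pentyl group exists here. In this assay a small step is expected, towards a lower number or none beyond the scatter, since the change keeps the shared core and only exchanges one group of similar size for another. Compound 4 is therefore estimated at 300 nM, with a range from 100 nM to 900 nM. The expected step of a 1.3-fold lower number from compound 2 to compound 4 (0.11 log units; within the scatter) is accordingly modest.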

Compound 4, half-maximal effective concentration: 178 nM
Compound 4: middle estimate off by 1.7-fold (0.23 log units), on the high side, and the stated range covers the measured number.
By their numbers in this assay, from the lowest: compound 3; then compounds 1 and 4 (each within the scatter of the next); then compound 2.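

In this assay, going by these compounds alone, the change from cyclohexyl to pentyl on the amide-type nitrogen gives a 2.2-fold lower number from compound 2 to compound 4 (0.34 log units; beyond the scatter) and so provides the first direct pair at this place. It shows that the number at this position responds to the group it carries, and that a pentyl chain with no ring can replace the six-membered carbon ring without raising the number. No measurement shown here accounts for the size or direction of this step.

A single pair cannot separate the loss of the ring from the loss of one carbon, and a cyclopentyl ring or a hexyl chain on the same nitrogen would bear on that question. Going by these compounds, how a chain ending in an amine or a carboxylic acid would behave at this position also remains open.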